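The compounds below may be only part of what the source reports. "The series", "measured", "known", "first", "only" and "open" are said of these compounds alone.

Going by the values given here, compound 2, with structure `O=C(O)CCCOc1ccc(OCc2ccc3ccccc3n2)cc1`, is the weaker of the two compounds measured so far. In an assay on membranes from lung (Cavia porcellus) for binding affinity to cysteinyl leukotriene receptor (Homo sapiens) (a higher number here means a weaker inhibitor, a lower number a stronger inhibitor), compound 2 gives 1200 nM. Among the compounds with values here, its only measured neighbour, compound 1, with structure `CCCC(CCC(=O)O)Cc1ccc(OCc2ccc3ccccc3n2)cc1`, sits far from it: in this assay compound 1 gives 21 nM, and the gap between these two values lies well beyond the usual scatter, with compound 2 standing at the high end.

The next compound, compound 3, with structure `CC(CCC(=O)O)Cc1ccc(OCc2ccc3ccccc3n2)cc1`, is derived from compound 2 by one change: 4-carboxy-2-methylbutyl in place of 3-carboxypropoxy on an aromatic carbon. Within the data shown here, the side chain thus moves away from the one that compound 2 carries and toward the one found in compound 1, differing from the latter only in the branch on the chain. Among the measured compounds shown here, no measured step covers this change directly, so the size of the expected move rests on the two known values alone.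

Given that compound 1 reaches 21 nM with a closely related chain, compound 3 is expected to move sharply toward stronger binding, by an estimated step of a 20-fold lower number from compound 2 to compound 3 (1.30 log units; beyond the scatter). For compound 3 the estimated value in this assay is 60 nM, within a range of 15 nM to 250 nM.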

Compound 3, inhibition constant: 43 nM
The estimate for compound 3 lay 1.4-fold (0.14 log units) above the measured number; the measured number falls inside the stated range.
By their numbers in this assay, from the lowest: compound 1; then compound 3; then compound 2.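

In this assay, putting 4-carboxy-2-methylbutyl in place of 3-carboxypropoxy on this aromatic carbon gives a large move (a 28-fold lower number from compound 2 to compound 3 (1.45 log units; beyond the scatter)), which shows that with the rest of the molecule unchanged, this one side chain can shift binding strongly. The branch on the chain matters far less: hydrogen in place of ethyl on a saturated chain carbon, three bonds along the chain from an aromatic carbon, gives only a modest step (a 2.0-fold higher number from compound 1 to compound 3 (0.31 log units; beyond the scatter)), so the shorter branch of compound 3 costs little next to the exchange of the whole side chain. No measurement shown here explains the size of either step.

From the compounds shown here alone, the exchange from compound 2 to compound 3 removes the oxygen on the aromatic carbon and adds the methyl branch in a single step, so the share of each remains open, and an unbranched 4-carboxybutyl chain at this position would be needed to separate them. Also open, going by these compounds, is how binding responds to a butyl branch on the chain, or to a tetrazole in place of the carboxylic acid.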